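This account rests on a few compounds, and the source may have more. Where it says the series, first, only, none or still open, it means among the compounds named here.

Of the compounds shown here, three have so far been measured in an assay on cell membranes for binding affinity to Adrenergic receptor alpha-1 (Rattus norvegicus), read by radioligand binding; a lower number here means a stronger inhibitor, a higher number a weaker inhibitor. Compound 1 `COc1ccccc1N1CCN(CCn2ncc(N3CCN(C(=O)c4ccco4)CC3)c(Cl)c2=O)CC1` gives 33 nM in this assay, compound 2 `O=C(c1ccco1)N1CCN(c2ccc(=O)n(CCN3CCN(c4ccccc4Cl)CC3)n2)CC1` gives 34 nM, and compound 3 `COc1ccccc1N1CCN(CCCn2nc(N3CCN(C(=O)c4ccco4)CC3)ccc2=O)CC1` gives 64.5 nM. Compound 3 holds the highest of the three numbers, but its nearest neighbour, compound 2, and its furthest, compound 1, both sit within the scatter of it, so the three values cannot be told apart on the evidence available.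

Compound 4 `O=C(c1ccco1)N1CCN(c2ccc(=O)n(CCCN3CCN(c4ccccc4Cl)CC3)n2)CC1` has not yet been measured in this assay. It differs from compound 3 by chloro in place of methoxy on an aromatic carbon. Among the measured compounds shown here, no single-point step between measured compounds is available for this swap on the core of compound 3. Compound 1, with 33 nM, and compound 2, with 34 nM, carry the same methoxy and chloro pair on their own cores and show no step beyond the scatter. On that basis the expected step is a 1.1-fold lower number from compound 3 to compound 4 (0.03 log units; within the scatter), none beyond the scatter in either direction. Compound 4 is therefore estimated to give about 60 nM in this assay, with a range from 30 nM to 130 nM.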

Compound 4, inhibition constant: 12.8 nM
Estimate against measurement, compound 4: 4.7-fold (0.67 log units) above, and the stated range ends above it.
By their numbers in this assay, from the lowest: compound 4; then compounds 1, 2 and 3 (each within the scatter of the next).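

On the core of compound 3, the change from 2-methoxyphenyl to 2-chlorophenyl gives a 5.0-fold lower number from compound 3 to compound 4 (0.70 log units; beyond the scatter) in this assay. Among the compounds shown here, this is the only step in the set where a single place changes, so it shows that the group on this aromatic carbon, ortho to a large group, can move the number beyond the usual scatter. Compounds 1 and 2 could not show this, since they differ in more than one place, and nothing measured here accounts for the size of the step.

Whether the same swap gives a comparable step on the cores of compound 1 and compound 2 cannot be read from these compounds, so the result holds only for the core of compound 3. Also open, on these data alone, is how a fluoro, methyl or hydroxyl group at this place would compare with chloro and methoxy, and how a longer chain to the piperazine would change the number when combined with the 2-chlorophenyl group.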